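The compounds below may be only part of what the source reports. "The series", "measured", "known", "first", "only" and "open" are said of these compounds alone.

Of the compounds shown here, three built on one shared core have been measured in an ADME assay on microsomes from liver (Homo sapiens) for metabolic stability; a lower number here means that the compound disappears faster, a higher number that the compound lasts longer. Compound 1, `O=C(O)c1cc(F)c2nc(N3CC4C(/C=C/c5c(-c6c(Cl)cccc6Cl)noc5C5CC5)C4C3)sc2c1`, gives 0.717 h in this assay. Compound 2, `O=C(O)c1cc(F)c2nc(N3CCC4(C=C(c5c(-c6c(Cl)cccc6Cl)noc5C5CC5)C4)CC3)sc2c1`, gives 0.85 h. Compound 3, `O=C(O)c1cc(F)c2nc(N3CCC(CCc4c(-c5c(Cl)cccc5Cl)noc4C4CC4)CC3)sc2c1`, gives 0.317 h. Among these three numbers compound 2 has the largest, though the gap to compound 1 lies within the usual scatter of repeated measurements, so the two cannot be told apart on this evidence; only the gap from compound 2 down to compound 3 lies beyond the scatter.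

The next compound, compound 4, `O=C(O)c1cc(F)c2nc(N3CCC4(C=C(c5c(-c6c(Cl)cncc6Cl)noc5C5CC5)C4)CC3)sc2c1`, keeps everything in compound 2 except for one exchange: 3,5-dichloropyridin-4-yl in place of 2,6-dichlorophenyl on an aromatic carbon. Within the three measured compounds no pair differs in exactly this way, so there is no measured step on which to rest a firm expectation for this exchange. Exchanges of one small aromatic group for another of the same size, as here, commonly move a half-life only modestly, so the expected step from compound 2 to compound 4 in this assay is a 1.1-fold higher number from compound 2 to compound 4 (0.02 log units; within the scatter), which is not expected to reach beyond the scatter in either direction. Compound 4 is therefore estimated to give about 0.9 h in this assay, within a range from 0.45 h to 1.8 h.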

Compound 4, half-life: 0.35 h
The estimate for compound 4 lay 2.6-fold (0.41 log units) above the measured number; measured number below the stated range.
By their numbers in this assay, from the lowest: compounds 3 and 4 (each within the scatter of the next); then compounds 1 and 2 (each within the scatter of the next).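

Among these compounds, this is the first measured step at this place, an aromatic carbon of the five-membered aromatic ring, next to the ring nitrogen, and it shows that the half-life in this assay responds to what sits there: 3,5-dichloropyridin-4-yl in place of 2,6-dichlorophenyl gives a 2.4-fold lower number from compound 2 to compound 4 (0.39 log units; beyond the scatter) in this single pair. The two groups have the same count of 8 heavy atoms and both carry 2 chlorine atoms, yet exchanging one ring carbon for a ring nitrogen, which also adds 1 hydrogen-bond acceptor, is enough to produce a step beyond the usual scatter. Nothing measured here bears on what lies behind this step.

The compounds shown leave open whether a group such as 2,6-difluorophenyl or 2-chlorophenyl at this place would keep the half-life of compound 2 or lose it as compound 4 does. They also leave open whether the same exchange would give a step of similar size on the core of compound 1 or of compound 3, so this result rests on one pair alone.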